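Formyl for methyl on a ring nitrogen

A few compounds are considered here, and "the series" means these few. Any claim that something is new, unique, unknown or untested is made for them only; others in the source may bear on it.

In a physicochemical assay for solubility, at pH 7.4 (on this read-out lower numbers stand for lower solubility and higher numbers for higher solubility), compound 3 (`CN1CCC[C@H](NC(=O)[C@H]2CN(S(=O)(=O)c3ccccc3)C[C@@H]2NC(=O)c2cc(-c3ccccc3Cl)on2)C1`) gives 503000 nM and stands level with compound 1 (`O=C(N[C@H]1CN(S(=O)(=O)c2ccccc2)C[C@@H]1C(=O)NC[C@@H]1CCCN1)c1cc(-c2ccccc2Cl)on1`) at 503000 nM as the joint highest of three numbers, while compound 2 (`CN(C(=O)[C@H]1CN(S(=O)(=O)c2ccccc2)C[C@@H]1NC(=O)c1cc(-c2ccccc2Cl)on1)[C@H]1CCCNC1`) gives 113000 nM in the same read-out. Compound 4 (`O=CN1CCC[C@H](NC(=O)[C@H]2CN(S(=O)(=O)c3ccccc3)C[C@@H]2NC(=O)c2cc(-c3ccccc3Cl)on2)C1`) carries one change from compound 3: formyl in place of methyl on an amine nitrogen in a ring. For the measured compounds named here, no measured step makes this exact change, so the measured steps serve only as a guide to size: a 4.5-fold lower number from compound 1 to compound 2 (0.65 log units; beyond the scatter) and a 4.5-fold higher number from compound 2 to compound 3 (0.65 log units; beyond the scatter) are modest, and no change at the digits printed from compound 1 to compound 3 (within the scatter) is no step at all. In this assay a modest drop of the same order is expected, estimated as a 3.0-fold lower number from compound 3 to compound 4 (0.47 log units; beyond the scatter) in size. Compound 4 is estimated at 170000 nM (expected range 50000 nM to 503000 nM).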

Compound 4, solubility: 4500 nM
For compound 4 the middle estimate is 38-fold (1.58 log units) above the measured one, and the stated range ends above it.
By their numbers in this assay, from the lowest: compound 4; then compound 2; then compounds 1 and 3 (each within the scatter of the next).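

In this assay, for the compounds shown here, the amine nitrogen in the ring proves a sensitive place: formyl in place of methyl gives a 110-fold lower number from compound 3 to compound 4 (2.05 log units; beyond the scatter) as a step larger than any among the earlier compounds. A large gap also shows against the other two compounds, with a 25-fold lower number from compound 2 to compound 4 (1.40 log units; beyond the scatter) and with a 110-fold lower number from compound 1 to compound 4 (2.05 log units; beyond the scatter) as well. No supporting measurement speaks to the reason for this fall.

From the compounds shown here alone, whether acetyl on the same ring nitrogen would fall as far stays open. So does whether a longer chain in place of methyl would move the number at all.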